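Removing the methyl group from the aryl ring of compound 2

A few compounds are considered here, and "the series" means these few. Any claim that something is new, unique, unknown or untested is made for them only; others in the source may bear on it.

In a functional assay on MCF7 cells (Homo sapiens), tested at 7.5 uM (a higher number here means a weaker effect of the compound at the concentration tested, a lower number a stronger effect), the measured compounds give the following:
compound 1 `C=CCOc1c(C)c(C)c2c(c1C)CCC(C)(COc1ccc(/C=C3\SC(=O)NC3=O)cc1Br)O2`: 105%
compound 2 `CC(C)=CCOc1c(C)c(C)c2c(c1C)CCC(C)(COc1ccc(/C=C3\SC(=O)NC3=O)cc1C)O2`: 27%
compound 3 `C=CCOc1c(C)c(C)c2c(c1C)CCC(C)(COc1cccc(/C=C3\SC(=O)NC3=O)c1)O2`: 75%

Compound 2 stands lowest of the three numbers in this assay, that is, it shows the strongest effect at the tested concentration. Its nearest neighbour is compound 3, whose number lies higher by an amount beyond the scatter, and the furthest is compound 1, higher still and also beyond the scatter. None of these three pairs differs in only one place, so no single step can be read from them; the numbers only show that compound 2 is set apart from both others.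

Compound 4 `CC(C)=CCOc1c(C)c(C)c2c(c1C)CCC(C)(COc1ccc(/C=C3\SC(=O)NC3=O)cc1)O2` has not yet been measured in this assay. It differs from compound 2 by hydrogen in place of methyl on an aromatic carbon. Because compound 2 gives 27% while every other compound with a different substitution on that ring gives a higher number, compound 4 is expected to lose some of the effect, with a step from compound 2 to compound 4 of a number 23 percentage points higher from compound 2 to compound 4 (beyond the scatter), upward and beyond the scatter. Compound 4 is therefore estimated at 50%, within a range from 25% to 85%.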

Compound 4, a percentage reported as activity, at one concentration (the size of the read-out at that concentration, not a potency): 5%
Estimate against measurement, compound 4: 45 percentage points above, outside the stated range (below it).
By their numbers in this assay, from the lowest: compound 4; then compound 2; then compound 3; then compound 1.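

The step from methyl to hydrogen gives a number 22 percentage points lower from compound 2 to compound 4 (beyond the scatter) in this assay, so the methyl group on this aromatic carbon, ortho to a large group, is not needed for the effect at the concentration tested, and the strongest effect of the series belongs to the compound that carries only hydrogen there. Within the data shown here, this is the first comparison in the set that isolates a single place, and it separates this one carbon from the other differences among the compounds, which the earlier numbers could not do. The size of the step is modest, and no measurement at hand says why the loss of this single heavy atom strengthens the effect.

The compounds shown leave open how an amine, a methoxy group or a carboxylic acid on this aromatic carbon would read in this assay. Going by these compounds, compound 1 carries bromine on this ring but also differs in its ether chain, so its number cannot be set against this step, and whether the same change holds with that other chain also stays open.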